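A few compounds are considered here, and "the series" means these few. Any claim that something is new, unique, unknown or untested is made for them only; others in the source may bear on it.

Measured compounds:

Compound 1 `NC1=NC2(CCOCC2)N(OCCCOc2ccc(F)cc2)C(N)=N1`: in an assay on isolated protein for inhibition of Dihydrofolate reductase (Homo sapiens), read by spectrophotometry, using NADPH, with stated times of 5 s and 6 min, tested at 5 uM (on this read-out higher numbers stand for a stronger effect at the one concentration tested and lower numbers for a weaker effect), compound 1 gives > 90%, which is a limit of the assay and not a number.
Compound 2 `Cc1cc(C)cc(OCCCON2C(N)=NC(N)=NC23CCOCC3)c1`: in this assay compound 2 gives 84.3%.
Compound 3 `NC1=NC2(CCSCC2)N(OCCCOc2cccc(Cl)c2Cl)C(N)=N1`: in this assay compound 3 gives 83.8%.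

Compound 2 and compound 3 sit within the scatter of each other, so no order between them can be read. Compound 1 stands at a limit (the limit of > 90% in this assay, at which 1 of the 3 values shown sits). Among the compounds with values here, the one step that touches the aryl group attached to the oxygen on the saturated carbon is a number at least 5.7 percentage points lower from compound 1 to compound 2 (that floor lies within the scatter), and its floor lies within the scatter.

Compound 4 `Cc1ccc(OCCCON2C(N)=NC(N)=NC23CCOCC3)cc1` differs from compound 2 as follows: 4-methylphenyl in place of 3,5-dimethylphenyl on an oxygen on a saturated carbon. Within the data shown here, the only comparable change, from compound 1 to compound 2, gave no step that can be separated from the scatter, so no step beyond the scatter is expected here either. In this assay compound 4 is expected to give 84%, between 74% and 92%. The step from compound 2 that this estimate means is expected to be a number 0.3 percentage points lower from compound 2 to compound 4 (within the scatter).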

Compound 4, a percentage reported as inhibition, at one concentration (the size of the read-out at that concentration, not a potency): > 90%
Compound 4 gave a limit, no number; the forecaster's own chance of this, stated with the estimate: 10%; middle value at least 6 percentage points from the limit.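

Replacing 3,5-dimethylphenyl with 4-methylphenyl on an oxygen on a saturated carbon gives, in this assay, a number at least 5.7 percentage points higher from compound 2 to compound 4 (that floor lies within the scatter). Until now only the 4-fluorophenyl compound stood at the top of the read-out; this position now also carries a methyl-bearing aryl group there, so reaching that level is not tied to fluoro. The value of compound 4 is a limit and not a number, as is that of compound 1, so the step between them cannot be read and methyl and fluoro cannot be ordered: the limit of > 90% in this assay, at which 2 of the 4 values shown sit.

From the compounds shown here alone, the order of compound 1 and compound 4 stays open at this one concentration. Also open, going by these compounds, is how an amine or a carboxylic acid in place of the methyl of 4-methylphenyl would read, or a longer chain on the aryl group.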